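This account rests on a few compounds, and the source may have more. Where it says the series, first, only, none or still open, it means among the compounds named here.

In a functional assay on PC-3 cells (Homo sapiens) for inhibition, read by sulforhodamine B assay (on this read-out higher numbers stand for weaker inhibition of growth and lower numbers for stronger inhibition of growth), the measured values are:
compound 1 `COc1ccc(-c2ccc(-c3ccc(-c4nc5cc(C)ccc5[nH]4)cc3)cc2)cc1OC` gives 2560 nM
compound 2 `FC(F)(F)c1ccc(-c2ccc(-c3ccc(-c4nc5ccccc5[nH]4)cc3)cc2)cc1` gives 45200 nM

Compound 2 at 45200 nM holds the higher of the two numbers and so shows the weaker inhibition of growth. Compound 1 at 2560 nM lies lower, and the gap is beyond the scatter. The two compounds differ in more than one place, so the gap cannot be assigned to any single change.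

The next compound is compound 3 `COc1ccc(-c2ccc(-c3ccc(-c4nc5ccccc5[nH]4)cc3)cc2)cc1` and its difference from compound 2 reads methoxy in place of trifluoromethyl on an aromatic carbon in the core-bearing structure, which is methoxy in place of trifluoromethyl on an aromatic carbon, para to a large group. Going by the values given here, no measured pair isolates this change. Among the compounds with values here, the only guide is compound 1 at 2560 nM which also carries methoxy and sits lower, though other differences remain. The expected move is a 6.5-fold lower number from compound 2 to compound 3 (0.81 log units; beyond the scatter) toward stronger inhibition of growth and beyond the scatter, with little certainty about its size. For compound 3 in this assay the estimated value is 7000 nM with a range of 2000 nM to 25000 nM expected.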

Compound 3, concentration for 50% growth inhibition: 100000 nM
Beside the measured number, compound 3's estimate is 14-fold (1.15 log units) below it; measured number outside the range, above it.
By their numbers in this assay, from the lowest: compound 1; then compound 2; then compound 3.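

In this assay, going by these compounds alone, this pair gives the first reading of a single change: the move from 4-(trifluoromethyl)phenyl to 4-methoxyphenyl, para to a large group, gives a 2.2-fold higher number from compound 2 to compound 3 (0.34 log units; beyond the scatter) and so a modest shift toward weaker inhibition of growth. On the core shared by these two compounds, methoxy at this position therefore brings no gain over trifluoromethyl, and the step runs in the opposite direction, leaving compound 3 with the highest number of the three. Nothing at hand bears on why the number moves in this direction.

Compound 1 differs from compound 3 in more than one place, so neither its second methoxy nor the methyl on its core can yet be credited with any share of its lower number. Going by these compounds, it also remains open how this position responds to a group of another kind, such as an amine, a carboxylic acid or a longer alkoxy chain, and whether the order of trifluoromethyl and methoxy holds on a core carrying that methyl.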